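This account rests on a few compounds, and the source may have more. Where it says the series, first, only, none or still open, it means among the compounds named here.

Measured so far in an assay on microsomes from liver for inhibition of sterol O-acyltransferase 1 (Rattus norvegicus); a higher number here means a weaker inhibitor, a lower number a stronger inhibitor: compound 1 `CCCCCCCn1nc(-c2ccccc2)c(-c2ccccc2)cc1=O` gives 86000 nM. Compound 3 `CCCCCCCNc1cc(-c2ccccc2)c(-c2ccccc2)nn1` gives 55000 nM. Compound 2 `O=c1cc(-c2ccccc2)c(-c2ccccc2)nn1C1CCCCC1` reaches only the limit > 300000 nM, so no number is known for it.

Compound 3 and compound 1 lie within the scatter of each other, so neither can be called the stronger inhibitor. Compound 4 `CCCCCCS(=O)(=O)c1cc(-c2ccccc2)c(-c2ccccc2)nn1` differs from compound 3 in one place: hexylsulfonyl in place of heptylamino on an aromatic carbon. Within the data shown here, the only measured step, an at least 3.4-fold higher number from compound 1 to compound 2 (0.54 log units; beyond the scatter), concerns a change on an aromatic nitrogen, not the group on the aromatic carbon, so it does not bear on this change. Among the measured compounds shown here, no measured step therefore points in either direction, and the expected step is a 1.5-fold higher number from compound 3 to compound 4 (0.16 log units; within the scatter), within the scatter. The estimate for compound 4 is 80000 nM, with a range from 20000 nM to 300000 nM.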

Compound 4, half-maximal inhibitory concentration: 60000 nM
Beside the measured number, compound 4's estimate is 1.3-fold (0.12 log units) above it; the measured number falls inside the stated range.
By their numbers in this assay, from the lowest: compounds 3, 4 and 1 (each within the scatter of the next). At a limit, above all of these: compound 2.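

Hexylsulfonyl in place of heptylamino on the aromatic carbon gives a 1.1-fold higher number from compound 3 to compound 4 (0.04 log units; within the scatter) in this assay and leaves compound 3 and compound 4 indistinguishable. This position therefore accepts a group with no hydrogen-bond donor, and with a sulfonyl in place of the amino link, without a readable difference from heptylamino. No measurement at hand bears on why the two groups match.

As far as these compounds go, the chain and its linking atom differ together here, so their separate contributions remain unknown. Also open, from the compounds shown here alone, is how a hexylamino group, a methylamino group or a carboxylic acid on this carbon would compare.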